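Swapping the aryl group in a series at its limit

A few compounds are considered here, and "the series" means these few. Any claim that something is new, unique, unknown or untested is made for them only; others in the source may bear on it.

Compound 2 (`COc1cc(-n2ncnc2-c2ccc(Cl)c(Cl)c2)cc(OC)c1OC`) gives > 10000 nM in a functional assay on MCF7 cells (Homo sapiens) for antiproliferative activity, read by MTT assay, with a stated time of 72 h (a lower number here means a stronger inhibitor, a higher number a weaker inhibitor), as a limit of the assay and not a number. The expectation below leans on compound 1 (`COc1cc(-c2ncnn2-c2ccc(F)cc2)cc(OC)c1OC`), which also carries 4-fluorophenyl and gives > 10000 nM as a limit of the same kind. Compound 2 therefore has no measured neighbour to be ranked against, and the overall position is the limit of > 10000 nM in this assay, at which 2 of the 2 values shown sit, so far in this series.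

Compound 3 (`COc1cc(-n2ncnc2-c2ccc(F)cc2)cc(OC)c1OC`) has 4-fluorophenyl in place of 3,4-dichlorophenyl on an aromatic carbon of the five-membered aromatic ring with 3 nitrogen (4-fluorophenyl in place of 3,4-dichlorophenyl on an aromatic carbon). Among the measured compounds shown here, no step between measured compounds is available to size this change in this assay directly. The step of a number no higher from compound 2 to compound 3 (the limit leaves the size open) is expected to stay within the usual scatter, with no clear direction. A reading at the limit again is the likeliest result, though a number close to it would not surprise. For compound 3 the estimated half-maximal inhibitory concentration is 10000 nM with an expected range of 2500 nM to 40000 nM in this series.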

Compound 3, half-maximal inhibitory concentration: > 10000 nM
Compound 3: a limit, no number; the forecaster's own chance of this, stated with the estimate: 65%; the middle value lies on the limit itself.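

Compound 2 and compound 3 both read as limits of the assay in this assay, not as numbers, so no step can be read between them. The compounds shown leave open whether 4-fluorophenyl and 3,4-dichlorophenyl differ at all in this assay, or whether any compound of this series gives a readable number, with the series standing so far at: the limit of > 10000 nM in this assay, at which 3 of the 3 values shown sit.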